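The source may hold more compounds than are shown below. What is called first, only, known or untested is meant among the compounds shown, and "the series" means these compounds.

Measured compounds:
Compound 1 `CCCCNC(=O)C1C(C(=O)O)[C@@H]2CC[C@H]1O2`: 10000 nM
Compound 2 `O=C(O)CCCNC(=O)C1C(C(=O)O)[C@@H]2CC[C@H]1O2`: 10000 nM
Compound 3 `O=C(O)CCCCCCCNC(=O)C1C(C(=O)O)[C@@H]2CC[C@H]1O2`: 10000 nM

Three compounds share one core and differ only in the chain on the amide nitrogen. In an ADME assay on SJ-G2 cells (Homo sapiens) for cytotoxicity, read by MTT assay, with a stated time of 72 h (a higher number here means a weaker inhibitor of growth, a lower number a stronger inhibitor of growth), compound 2 gives 10000 nM, and compound 1, which differs by methyl in place of carboxy on a saturated chain carbon, three bonds along the chain from an amide-type nitrogen, shows no change at the digits printed from compound 2 to compound 1 (within the scatter). Compound 3 differs from compound 2 by 4-carboxybutyl in place of carboxy on a saturated chain carbon, three bonds along the chain from an amide-type nitrogen, and between them no change at the digits printed from compound 2 to compound 3 (within the scatter); from compound 1 to compound 3 the record is no change at the digits printed from compound 1 to compound 3 (within the scatter). All three thus sit level with one another in this assay.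

Compound 4 `CCCCCCCCNC(=O)C1C(C(=O)O)[C@@H]2CC[C@H]1O2` is not yet measured. It differs from compound 3 by methyl in place of carboxy on a saturated chain carbon, seven bonds along the chain from an amide-type nitrogen. For the measured compounds named here, this is the same kind of change as the one from compound 2 to compound 1, but the place differs: there the carbon was three bonds along the chain from an amide-type nitrogen, here it is seven bonds along. Beside the earlier step, no change at the digits printed from compound 2 to compound 1 (within the scatter), the expected step is no change at the digits printed from compound 3 to compound 4 (within the scatter), resting on that step and on the fact that compound 1, compound 2 and compound 3 all sit level. Compound 4 is therefore estimated at 10000 nM, with a range from 5000 nM to 20000 nM.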

Compound 4, concentration for 50% growth inhibition: 10000 nM
The estimate for compound 4 equals the measured number at the digits printed; low and high end bracket the measured number.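

In this assay, methyl in place of carboxy on a saturated chain carbon, seven bonds along the chain from an amide-type nitrogen, gives no change at the digits printed from compound 3 to compound 4 (within the scatter), while the same change three bonds along gives no change at the digits printed from compound 2 to compound 1 (within the scatter). Set side by side, the two steps agree: the same change on two cores in this assay, no change at the digits printed (within the scatter) from compound 2 to compound 1 and no change at the digits printed (within the scatter) from compound 3 to compound 4, 1.0-fold (0.00 log units) apart, within the scatter of two such steps The other new comparisons read the same, with no change at the digits printed from compound 2 to compound 4 (within the scatter) and no change at the digits printed from compound 1 to compound 4 (within the scatter), so the change carries from the shorter chain to the longer one without a readable step, but with all four compounds level this does not show that it would carry over where a step of real size exists.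

The compounds shown leave open whether an amine or a phenyl ring at the end of the chain, or a longer chain, would shift the read-out from the level of compound 4 at 10000 nM. They also leave open what an ester in place of the carboxylic acid on the shared core would do.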